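The source may report more compounds than this note shows. Statements on the series, on what has been measured and on what is new or still open speak of the compounds shown alone.

Compound 3 `O=C(O)CC(Cc1csc(CCCc2ccc3c(n2)NCCC3)n1)c1cnc(C2CC2)s1` is the starting point of this step. In an in vivo ADME assay on the whole organism for pharmacokinetics, with Rattus norvegicus as the target (on this read-out higher numbers stand for higher oral bioavailability and lower numbers for lower oral bioavailability), compound 3 gives > 100%, which is a limit of the assay rather than a number, and the same holds for (the limit of > 100% in this assay, at which 1 of the 3 values shown sits). Its two measured neighbours differ from it only in the group on the saturated chain carbon: compound 1 `COc1cc(OC)cc(C(CC(=O)O)Cc2csc(CCCc3ccc4c(n3)NCCC4)n2)c1` gives 98% in this assay, and compound 2 `COc1ccc(C(CC(=O)O)Cc2csc(CCCc3ccc4c(n3)NCCC4)n2)cc1F` gives 95%. The steps of a number at least 2 percentage points higher from compound 1 to compound 3 (that floor lies within the scatter) and a number at least 5 percentage points higher from compound 2 to compound 3 (that floor lies within the scatter) both carry only a floor, and the step of a number 3 percentage points lower from compound 1 to compound 2 (within the scatter) lies within the scatter, so these three compounds sit together at the upper end of this assay.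

Compound 4 `COCc1ncc(C(CC(=O)O)Cc2csc(CCCc3ccc4c(n3)NCCC4)n2)s1` keeps the thiazolyl of compound 3 and changes only its substituent: methoxymethyl in place of cyclopropyl on an aromatic carbon. Among the measured compounds shown here, no measured step alters a group on that thiazolyl, so the closest guide is that the three measured exchanges at this chain position left this assay unchanged beyond the scatter. Compound 4 is therefore expected to stay high, with an estimated step of a number at least 10 percentage points lower from compound 3 to compound 4 (that floor lies within the scatter). Compound 4 is estimated at 90%, between 70% and 100%.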

Compound 4, oral bioavailability: 90%
Estimate against measurement, compound 4: no gap at the digits printed; low and high end bracket the measured number.
By their numbers in this assay, from the lowest: compounds 4, 2 and 1 (each within the scatter of the next). At a limit, above all of these: compound 3.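

Among the compounds shown here, this result is the first to change the substituent on the thiazolyl rather than the whole group on the saturated chain carbon, and in this assay methoxymethyl in place of cyclopropyl on an aromatic carbon gives a number at least 10 percentage points lower from compound 3 to compound 4 (that floor lies within the scatter). That step carries only a floor because compound 3 stands at a limit of the assay: the limit of > 100% in this assay, at which 1 of the 4 values shown sits.

The exchanges of the whole group also stay inside the scatter, with a number 5 percentage points lower from compound 2 to compound 4 (within the scatter) and a number 8 percentage points lower from compound 1 to compound 4 (within the scatter), so this open-chain substituent leaves the value in the same high range as the two phenyl-bearing compounds.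

Going by these compounds, what remains open is whether an amine, a carboxylic acid or a longer chain on this aromatic carbon would keep oral bioavailability this high. On these data alone, the true size of the change from cyclopropyl to methoxymethyl also remains unknown.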